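A Hydroxy for Fluoro Swap in an Arylpiperazine Pair

The source may report more compounds than this note shows. Statements on the series, on what has been measured and on what is new or still open speak of the compounds shown alone.

Compound 1, `Cc1cccc(N(C)CCCN2CCN(c3ccccc3)CC2)c1`: in an assay on HEK293 cells for displacement of a labelled ligand from 5-hydroxytryptamine receptor 7 (Homo sapiens), read by scintillation counting, with a stated time of 30 min (on this read-out higher numbers stand for weaker inhibition and lower numbers for stronger inhibition), compound 1 gives 84.8 nM.
Compound 2, `CN(CCCN1CCN(c2ccccc2)CC1)c1cccc(F)c1`: in this assay compound 2 gives 112 nM.

For the measured compounds named here, compound 2 stands at the higher of the two numbers measured so far, with compound 1 nearest to it; the step of a 1.3-fold higher number from compound 1 to compound 2 (0.12 log units; within the scatter) is within the scatter, so the two cannot be ranked against each other.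

Compound 3, `CN(CCCN1CCN(c2ccccc2)CC1)c1cccc(O)c1`, has not yet been measured in this assay. It differs from compound 2 as follows: hydroxy in place of fluoro on an aromatic carbon.

Going by the values given here, no measured step involves a hydroxy group, so nothing bears directly on this change. Among the compounds with values here, the only step available, a 1.3-fold higher number from compound 1 to compound 2 (0.12 log units; within the scatter), shows that exchanging one small group for another at the same aromatic carbon moved the number by less than the scatter. On that basis the step of a 1.3-fold higher number from compound 2 to compound 3 (0.13 log units; within the scatter) is expected to be modest, with a slight lean toward a higher number given the uncertainty of an untested group. Compound 3 is therefore estimated at 150 nM, in a range from 50 nM to 450 nM.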

Compound 3, inhibition constant: 20 nM
For compound 3 the middle estimate is 7.5-fold (0.88 log units) above the measured one, and the stated range ends above it.
By their numbers in this assay, from the lowest: compound 3; then compounds 1 and 2 (each within the scatter of the next).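

In this assay, the change from 3-fluorophenyl to 3-hydroxyphenyl gives a 5.6-fold lower number from compound 2 to compound 3 (0.75 log units; beyond the scatter), and hydroxy in place of methyl on the same aromatic carbon gives a 4.2-fold lower number from compound 1 to compound 3 (0.63 log units; beyond the scatter). Both steps lie beyond the scatter and run in the same direction, so this position does respond to the group placed on it, which the step between methyl and fluoro, within the scatter, could not show. The hydroxy group brings one hydrogen-bond donor and one hydrogen-bond acceptor where fluoro has none, but no measurement here accounts for the lower number of compound 3.

The compounds shown leave open whether other groups on this carbon, such as methoxy or an amine, would give a number close to that of compound 3 or one close to those of compound 1 and compound 2. They also leave open whether hydroxy would give a similar step on another carbon of this ring, or in a compound with a longer chain in place of the present one.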